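Replacing 4-cyanophenyl with 2-phenylethenyl on compound 3

The compounds below may be only part of what the source reports. "The series", "measured", "known", "first", "only" and "open" are said of these compounds alone.

In an ADME assay on A549 cells (Homo sapiens) for cytotoxicity, read by MTT assay, with a stated time of 48 h (a lower number here means a stronger inhibitor, a higher number a weaker inhibitor), compound 1 (`Cc1ccc(-c2nnc(-c3cc4ccccc4nc3C)o2)cc1`) gives 175 ug/mL on this cell line, and compound 2 (`Cc1nc2ccccc2cc1-c1nnc(-c2ccc(OC(F)(F)F)cc2)o1`) gives 91.1 ug/mL in the same test. Compound 3 (`CC(=O)N1N=C(c2cc3ccccc3nc2C)CC1c1ccc(C#N)cc1`) has a different core from these two and is reported only as a limit, with > 200 ug/mL as its entry and no number behind it. It therefore stands at the limit of > 200 ug/mL in this assay, at which 1 of the 3 values shown sits, and its true distance from the other two is not known.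

Compound 4 (`CC(=O)N1N=C(c2cc3ccccc3nc2C)CC1/C=C/c1ccccc1`) differs from compound 3 at one place, with 2-phenylethenyl in place of 4-cyanophenyl on a saturated ring carbon. Among the compounds with values here, no measured step covers this exchange. Within the data shown here, the only step available is a 1.9-fold lower number from compound 1 to compound 2 (0.28 log units; within the scatter) and it concerns another core and another kind of group. With that single step to go on, no change beyond the scatter is expected in this assay and no direction can be given.

The expected move is an at least 1.0-fold lower number from compound 3 to compound 4 (0.02 log units; that floor lies within the scatter) and it should be read as an estimate from a limit and not from a number. For compound 4 the estimated value is 190 ug/mL with an expected range from 90 ug/mL to 350 ug/mL in this test, and a second result given only as a limit is about as likely as a number.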

Compound 4, half-maximal inhibitory concentration: 93.3 ug/mL
Compound 4: the middle estimate sits 2.0-fold (0.31 log units) above what was measured; low and high end bracket the measured number.
By their numbers in this assay, from the lowest: compounds 2, 4 and 1 (each within the scatter of the next). At a limit, above all of these: compound 3.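

In this assay, within the data shown here, putting 2-phenylethenyl in place of 4-cyanophenyl on the saturated ring carbon gives an at least 2.1-fold lower number from compound 3 to compound 4 (0.33 log units; beyond the scatter), so this position responds to the exchange by more than the scatter, which the only earlier step, a 1.9-fold lower number from compound 1 to compound 2 (0.28 log units; within the scatter), did not show on its own core and with its own groups. Both groups carry one six-membered aromatic ring of carbon only, so the step goes with swapping a nitrile on that ring for a double bond outside it, and these two parts of the change cannot be told apart here. Compound 3 is a limit and not a number, so the step is only a floor and its full size remains unknown: the limit of > 200 ug/mL in this assay, at which 1 of the 4 values shown sits.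

The compounds shown leave open whether the double bond itself matters, which a phenylethyl group at the same carbon would test, and whether an amine or a carboxylic acid on the phenyl ring of 2-phenylethenyl would keep the step. They also leave open whether the step would hold if a longer acyl chain replaced the acetyl group on the ring nitrogen.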